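The source may report more compounds than this note shows. Statements on the series, on what has been measured and on what is new or still open speak of the compounds shown alone.

Compound 2 `CC(C(=O)NCc1ccc(C(F)(F)F)nc1N1CCCCCCC1)c1ccc(NS(C)(=O)=O)c(F)c1` gives 0.7 nM in a functional assay on CHO-K1 cells for antagonist activity at transient receptor potential cation channel subfamily V member 1 (Homo sapiens), read by FLIPR (on this read-out higher numbers stand for weaker inhibition and lower numbers for stronger inhibition), the lowest of the two numbers recorded, with compound 1 `CC(C(=O)NCc1ccc(C(F)(F)F)nc1N1CCCCCC1)c1ccc(NS(C)(=O)=O)c(F)c1` nearest at 0.8 nM. Within the data shown here, the single measured step, a 1.1-fold lower number from compound 1 to compound 2 (0.06 log units; within the scatter), stays within the scatter. Compound 3 `CC(C(=O)NCc1ccc(C(F)(F)F)nc1N1CCN(C2CCCCC2)CC1)c1ccc(NS(C)(=O)=O)c(F)c1` carries a group of 12 heavy atoms (10 carbon, 2 nitrogen; one six-membered non-aromatic ring of carbon only, one six-membered non-aromatic ring with 2 hetero atoms) in place of a group of 8 heavy atoms (7 carbon, 1 nitrogen; one eight-membered non-aromatic ring with 1 hetero atom), on an aromatic carbon. Among the measured compounds shown here, this change is larger than the one between compound 1 and compound 2, and no measured step covers a group of this kind, so the flat step from compound 1 to compound 2 is the only guide. For compound 3 the expected step is a 2.9-fold higher number from compound 2 to compound 3 (0.46 log units; beyond the scatter), a number that is estimated rather than measured. Compound 3 is estimated at 2 nM, with a range of 0.5 nM to 10 nM.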

Compound 3, inhibition constant: 21.6 nM
Estimate against measurement, compound 3: 11-fold (1.03 log units) below; the measured number lies above the stated range.
By their numbers in this assay, from the lowest: compounds 2 and 1 (each within the scatter of the next); then compound 3.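

This position is not indifferent to the group placed on it: in this assay 4-cyclohexylpiperazin-1-yl brings a 31-fold higher number from compound 2 to compound 3 (1.49 log units; beyond the scatter) and a 27-fold higher number from compound 1 to compound 3 (1.43 log units; beyond the scatter) while the exchange between the two single-ring groups stayed within the scatter. The flat response between compound 1 and compound 2 therefore does not extend to this larger two-ring group with its second ring nitrogen. No measured evidence accounts for the rise. As far as these compounds go, whether the cyclohexyl or the piperazine ring is responsible remains open; 4-methylpiperazin-1-yl and 4-cyclohexylpiperidin-1-yl would separate the two.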